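Swapping a Thiourea for a Cyanoguanidine on the Pentyl Chain

The source may hold more compounds than are shown below. What is called first, only, known or untested is meant among the compounds shown, and "the series" means these compounds.

compound 1 `CC/N=C(\S)NCCCCCn1nc(-c2ccccc2)ccc1=O`: 66.4%
compound 2 `C/N=C(/NC#N)N(C)CCCCn1nc(-c2ccccc2)ccc1=O`: 27%
compound 3 `N#CNC(=N)NCCCCn1nc(-c2ccccc2)ccc1=O`: 61.2%

In a functional assay on the whole organism with Rattus norvegicus as the target, at a dose of 100 mg/kg (a higher number here means more inhibition at the dose given (going by the name of the read-out), a lower number less inhibition), compound 1 stands highest of the three numbers. Compound 3 sits close to it, as a number 5.2 percentage points lower from compound 1 to compound 3 (within the scatter) shows, while compound 2 lies far below, as a number 39.4 percentage points lower from compound 1 to compound 2 (beyond the scatter) shows. Compound 4 `CC/N=C(/NC#N)NCCCCCn1nc(-c2ccccc2)ccc1=O` differs from compound 1 in one place: a group of 7 heavy atoms (4 carbon, 3 nitrogen; no ring) in place of a group of 5 heavy atoms (3 carbon, 1 nitrogen, 1 sulfur; no ring), on an amine nitrogen. The step from compound 1 to compound 3 bears most directly on this change, since it also brings in a cyanoguanidine-type group, and it stayed within the scatter. Compound 2 also carries an extra methyl group that compound 4 does not share, so its large drop weighs less. Compound 4 is therefore expected to give 58%, between 36% and 78%, an expected step of a number 8.4 percentage points lower from compound 1 to compound 4 (within the scatter) within the scatter.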

Compound 4, a percentage reported as inhibition, in the whole organism at one dose (the size of the read-out at that dose, not a potency): 48.2%
For compound 4 the middle estimate is 9.8 percentage points above the measured one; low and high end bracket the measured number.
By their numbers in this assay, from the lowest: compound 2; then compound 4; then compounds 3 and 1 (each within the scatter of the next).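

Here the pentyl chain and ethyl group stay unchanged, and only the thiourea gives way to the cyanoguanidine on the amine nitrogen: this assay records a number 18.2 percentage points lower from compound 1 to compound 4 (beyond the scatter) as a modest loss. The earlier steps shown here from compound 1 also altered the chain, so they could not show that this swap alone costs inhibition beyond the scatter. Nothing measured here explains the loss. From the compounds shown here alone, whether a urea at this place, or a hexyl chain carrying the cyanoguanidine, would keep the inhibition of compound 1 remains open.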